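The compounds below may be only part of what the source reports. "The series", "measured", "known", "first", "only" and "open" are said of these compounds alone.

Compound 1 `COc1ccc(-c2cc3c(OC)cc(OC)cc3n(C)c2=O)cc1`: 10000 nM
Compound 2 `COc1ccc(-c2cc3c(OC)cc(OC)cc3n(CC(=O)O)c2=O)cc1`: 10000 nM
Compound 3 `COc1ccc(-c2cc3c(OC)cc(OC)cc3n(CCC#N)c2=O)cc1`: 10000 nM

In a functional assay on A-427 cells (Homo sapiens) for cytotoxicity, read by colorimetric assay and MTT assay (a higher number here means a weaker inhibitor, a lower number a stronger inhibitor), compound 1 gives 10000 nM and stands level with compounds 2 and 3. Compound 4 `CCN(CC)C(=O)CCn1c(=O)c(-c2ccc(OC)cc2)cc2c(OC)cc(OC)cc21` differs from compound 1 by (diethylcarbamoyl)methyl in place of hydrogen on a saturated chain carbon bound to an aromatic nitrogen. Two measured steps alter the same place on the shared core and therefore bear directly on this change: no change at the digits printed from compound 1 to compound 2 (within the scatter) and no change at the digits printed from compound 1 to compound 3 (within the scatter). The remaining pair shows no change at the digits printed from compound 2 to compound 3 (within the scatter). Within the data shown here, all three steps lie within the scatter, so nothing among the measured compounds points to a move in either direction. The step to compound 4 is therefore expected to be no change at the digits printed from compound 1 to compound 4 (within the scatter), no larger than the scatter. Compound 4 is estimated at 10000 nM, within a range from 5000 nM to 20000 nM.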

Compound 4, half-maximal inhibitory concentration: 10000 nM
Compound 4: middle estimate and measured number agree at the digits printed, within the range that was stated.
By their numbers in this assay, from the lowest: compounds 1, 2, 3 and 4 (each within the scatter of the next).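

In this assay, the step to the (diethylcarbamoyl)methyl group, with its 8 heavy atoms and no ring, shows that a substituent of this size at this place still leaves the reading flat (no change at the digits printed from compound 1 to compound 4 (within the scatter)). The amide chain also stands level with the nitrile chain (no change at the digits printed from compound 3 to compound 4 (within the scatter)) and with the carboxy chain (no change at the digits printed from compound 2 to compound 4 (within the scatter)). No measurement offers an explanation for this flatness.

As far as these compounds go, what an amine or a benzyl group would do on this chain remains open. So does whether any change elsewhere on the shared core would move the reading.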